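This account rests on a few compounds, and the source may have more. Where it says the series, first, only, none or still open, it means among the compounds named here.

Compound 1 `OCc1cn(Cc2ccc(Cl)cc2)c2ccccc12`: 79 nM
Compound 2 `CC(=O)OCc1cn(Cc2ccc(Cl)cc2)c2ccccc12`: 63 nM
Compound 3 `O=C(NC1CCCCC1)OCc1cn(Cc2ccc(Cl)cc2)c2ccccc12`: not yet measured

Both measured compounds were tested in a functional assay on T29Kt1 cells (Homo sapiens) for cytotoxicity, read by sulforhodamine B assay, with a stated time of 3 days; on this read-out lower numbers stand for stronger inhibition and higher numbers for weaker inhibition. Going by the values given here, there, compound 2 gives 63 nM, and this number lies within the usual scatter of the one for compound 1, so the two cannot be told apart.

Compound 3 differs from compound 2 in one place: cyclohexylamino in place of methyl on a carbonyl carbon. Put simply, cyclohexylamino stands in place of methyl on a carbonyl carbon, which turns acetyl into cyclohexylcarbamoyl.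

Among the compounds with values here, only one measured step bears on this change: a 1.3-fold lower number from compound 1 to compound 2 (0.10 log units; within the scatter). It is small and within the scatter, and it shows that acetyl in place of hydrogen on that oxygen left the number effectively unchanged. Within the data shown here, no measured compound carries cyclohexylcarbamoyl, however, so this step is only a loose guide.

A modest move towards a higher number, meaning weaker inhibition, is therefore expected, with the estimated step being a 2.4-fold higher number from compound 2 to compound 3 (0.38 log units; beyond the scatter). The estimate in this assay for compound 3 is 150 nM, with an expected range from 35 nM to 800 nM.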

Compound 3, half-maximal inhibitory concentration: 200 nM
Compound 3: the middle estimate sits 1.3-fold (0.12 log units) below what was measured; the measured number falls inside the stated range.
By their numbers in this assay, from the lowest: compounds 2 and 1 (each within the scatter of the next); then compound 3.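

In this assay, the oxygen on the saturated carbon had so far shown no readable change with acetyl, but cyclohexylcarbamoyl gives the first step at this position that lies beyond the scatter: a 2.5-fold higher number from compound 1 to compound 3 (0.40 log units; beyond the scatter). The change on the carbonyl carbon, cyclohexylamino in place of methyl, gives a step of similar standing, a 3.2-fold higher number from compound 2 to compound 3 (0.50 log units; beyond the scatter), so this position accepts a group with a six-membered ring at only a modest cost in this cell read-out. The change brings in more heavy atoms, a ring, a nitrogen and a hydrogen-bond donor all at once, and no separate measurement is available to explain the rise in the number.

The compounds shown leave open whether the ring or the nitrogen with its hydrogen goes with the higher number, and methylamino or cyclohexyl on the same carbonyl carbon would help to tell these apart. Also open, from the compounds shown here alone, is how phenylamino or a straight chain such as hexylamino would read at this carbon in this assay.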